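Sigma-1 binding: ester removal in the fluoropyrimidinyl-piperazine series

A few compounds are considered here, and "the series" means these few. Any claim that something is new, unique, unknown or untested is made for them only; others in the source may bear on it.

Measured compounds:
compound 1 `CC(=O)OC(CCCN1CCN(c2ncc(F)cn2)CC1)c1ccc(F)cc1` — 227 nM
compound 2 `O=C(OC(CCCN1CCN(c2ncc(F)cn2)CC1)c1ccc(F)cc1)c1ccccc1` — 3500 nM

In an assay (Cavia porcellus) for displacement of a labelled ligand from Sigma non-opioid intracellular receptor 1 (Homo sapiens) (on this read-out lower numbers stand for stronger inhibition and higher numbers for weaker inhibition), compound 2 gives 3500 nM, the highest of the two numbers recorded; the nearest is compound 1, which gives 227 nM. For the measured compounds named here, the only measured step, a 15-fold higher number from compound 1 to compound 2 (1.19 log units; beyond the scatter), is phenyl in place of methyl on a carbonyl carbon, i.e. the larger acyl group carries the weaker number.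

Compound 3 `Fc1ccc(CCCCN2CCN(c3ncc(F)cn3)CC2)cc1` has not been measured. It differs from compound 2 as hydrogen in place of benzoyloxy on a saturated chain carbon bound to an aromatic carbon and a saturated chain carbon, so the whole ester is gone and only the plain chain links the aromatic ring to the basic nitrogen.

The measured step bears only indirectly: it shows that shrinking the acyl group lowers the number, and removing the acyloxy entirely is taken as going further in that direction. A step of the order of a 23-fold lower number from compound 2 to compound 3 (1.37 log units; beyond the scatter) is therefore expected, downward. Compound 3 is estimated at 150 nM, within 30 nM to 1000 nM.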

Compound 3, half-maximal inhibitory concentration: 23 nM
Compound 3: the middle estimate sits 6.5-fold (0.81 log units) above what was measured; the whole stated range lies above it.
By their numbers in this assay, from the lowest: compound 3; then compound 1; then compound 2.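

Within the ester pair, the acyl group changed the number; the new result concerns the acyloxy group as a whole. In this assay, hydrogen in its place on this saturated chain carbon gives a 150-fold lower number from compound 2 to compound 3 (2.18 log units; beyond the scatter) and also a 9.9-fold lower number from compound 1 to compound 3 (0.99 log units; beyond the scatter), so neither ester is needed for binding at this level, and the plain chain of compound 3 carries the lowest number of the three. The order runs hydrogen, acetoxy, benzoyloxy on these three compounds alone, and no supporting data bear on why it does so.

Where a hydroxyl group on the same carbon would fall in that order remains open. So does whether the low number of compound 3 holds with a longer chain to the piperazine nitrogen.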